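Hydroxyphenyl isomers: from compound 2 to compound 3

The compounds below may be only part of what the source reports. "The series", "measured", "known", "first", "only" and "open" are said of these compounds alone.

In a functional assay on HCT-15 cells (Homo sapiens) for cytotoxicity (on this read-out higher numbers stand for weaker inhibition of growth and lower numbers for stronger inhibition of growth), two compounds have been measured so far. Compound 1 `OCCCCC#Cc1ccccc1C#Cc1cccs1` gives 13100 nM, and compound 2 `OCCCCC#Cc1ccccc1C#Cc1cccc(O)c1` gives 13600 nM. These values lie within the scatter of each other, so compound 2 stands level with compound 1 and no order can be drawn between them.

The next compound is compound 3 `OCCCCC#Cc1ccccc1C#Cc1ccc(O)cc1`, which has the same atoms as compound 2, joined differently: 4-hydroxyphenyl in place of 3-hydroxyphenyl on a triple-bonded carbon. For the measured compounds named here, the only measured step that bears on this change is a 1.0-fold higher number from compound 1 to compound 2 (0.02 log units; within the scatter). That step replaces thiophen-2-yl with 3-hydroxyphenyl on the same triple-bonded carbon, so it is only an indirect guide. Going by the values given here, no measured pair compares 3-hydroxyphenyl with 4-hydroxyphenyl directly. On this thin evidence, no step beyond the scatter is expected in this assay, and no direction is favoured. The expected step is a 1.0-fold lower number from compound 2 to compound 3 (0.02 log units; within the scatter). For compound 3 the estimated value is 13000 nM, with an expected range of 6000 nM to 28000 nM.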

Compound 3, concentration for 50% growth inhibition: 14100 nM
Beside the measured number, compound 3's estimate is 1.1-fold (0.04 log units) below it, and the stated range covers the measured number.
By their numbers in this assay, from the lowest: compounds 1, 2 and 3 (each within the scatter of the next).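

Working from this assay, the direct isomer comparison gives a 1.0-fold higher number from compound 2 to compound 3 (0.02 log units; within the scatter) and so separates 4-hydroxyphenyl from 3-hydroxyphenyl on a triple-bonded carbon by no more than the scatter. The comparison with the thiophen-2-yl compound gives a 1.1-fold higher number from compound 1 to compound 3 (0.03 log units; within the scatter) and adds a second hydroxyphenyl isomer to the earlier single replacement, again without a step beyond the scatter. Across compounds 1, 2 and 3, the three groups at this place therefore cannot be ranked, and the location of the hydroxyl on the phenyl ring makes no readable difference between compound 2 and compound 3. Nothing available offers an explanation for these results.

Still open, going by these compounds, is whether any group at this place can produce a step beyond the scatter, for example an amine or a carboxylic acid in place of the hydroxyl on the phenyl ring. The compounds shown also leave open whether a longer chain on the other triple-bonded carbon of the shared core would alter the growth-inhibition read-out, or whether the hydroxyphenyl isomers would remain level on such a changed core.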